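Swapping a Furan for a Pyridine in an Antiproliferative Series

The source may report more compounds than this note shows. Statements on the series, on what has been measured and on what is new or still open speak of the compounds shown alone.

Measured compounds:
- compound 1, `N#Cc1ccc(N2CCCc3c(-c4cccnc4)cccc32)cc1C(F)(F)F`: 13500 nM
- compound 2, `CCN(c1ccc(C#N)c(Cl)c1)c1cc(-c2ccoc2)ccc1C`: 4010 nM
- compound 3, `CCN(c1ccc(C#N)c(Cl)c1)c1cc(-c2cnc3ccccc3c2)ccc1C`: 25300 nM

All three were tested in a functional assay on VCaP cells (Homo sapiens) for antiproliferative activity, read by CCK-8 assay, with a stated time of 6 days; on this read-out higher numbers stand for weaker inhibition and lower numbers for stronger inhibition. Compound 2 gives the lowest number of the three, 4010 nM, and so is the most potent measured compound here. Compound 1 is the nearest to it, with 13500 nM, a gap beyond the usual scatter; compound 3 lies furthest away, with 25300 nM, also beyond the scatter. Compound 1 and compound 3 differ in both the shared core and the attached ring, so their two values can only be set side by side without reading a single cause into the gap.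

The next compound, compound 4, `CCN(c1ccc(C#N)c(Cl)c1)c1cc(-c2cccnc2)ccc1C`, keeps the core of compound 2 and changes only the ring that hangs from it: pyridin-3-yl in place of furan-3-yl on an aromatic carbon. Among the measured compounds shown here, no pair of measured compounds shows this exact change, so its size is open. The step from compound 2 to compound 4 is expected to be small, leaning toward weaker inhibition, a 1.5-fold higher number from compound 2 to compound 4 (0.18 log units; within the scatter). In this assay compound 4 is therefore estimated at 6000 nM, within a range from 2000 nM to 20000 nM.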

Compound 4, half-maximal inhibitory concentration: 1270 nM
Estimate against measurement, compound 4: 4.7-fold (0.67 log units) above; the measured number lies below the stated range.
By their numbers in this assay, from the lowest: compound 4; then compound 2; then compounds 1 and 3 (each within the scatter of the next).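

In this assay, placing pyridin-3-yl in place of furan-3-yl on this aromatic carbon gives a 3.2-fold lower number from compound 2 to compound 4 (0.50 log units; beyond the scatter), so the position responds to the choice of ring, and compound 4 now holds the lowest number among the compounds shown. The two rings match in their counts of hydrogen-bond donors and acceptors and neither carries a net charge, so these counts do not separate them, although the step is beyond the scatter. Nothing available explains why the pyridine ring gives the lower number.

Going by these compounds, whether a plain phenyl ring or pyridin-4-yl on this same carbon would give a higher or lower number remains open, and with it the question of whether the ring nitrogen and its place in the ring matter. Also open, on these data alone, are the effect of a small substituent such as an amine or a methoxy group on the pyridine ring, and whether the same swap would give a step of similar size on the core of compound 1, which also carries pyridin-3-yl.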